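Phenyl for pyridin-2-yl on the ring-nitrogen arm

The source may report more compounds than this note shows. Statements on the series, on what has been measured and on what is new or still open speak of the compounds shown alone.

The series shares one core and varies the group on a saturated chain carbon bound to an amide-type nitrogen in a ring. Compound 1 `CS(=O)(=O)Nc1ccc2c(c1)S(=O)(=O)N=C(C1=C(O)C3CCCC3N(CC3CCC3)C1=O)N2` carries cyclobutyl there; in an in vitro ADME assay on microsomes from liver (Homo sapiens) for metabolic stability (on this read-out lower numbers stand for a shorter-lived compound and higher numbers for a longer-lived compound), compound 1 gives 0.0667 h. Compound 2 `CS(=O)(=O)Nc1ccc2c(c1)S(=O)(=O)N=C(C1=C(O)C3CCCC3N(Cc3cccc(F)c3)C1=O)N2` carries 3-fluorophenyl, and in this assay compound 2 gives 0.85 h, the step being a 13-fold higher number from compound 1 to compound 2 (1.11 log units; beyond the scatter). Compound 3 `CS(=O)(=O)Nc1ccc2c(c1)S(=O)(=O)N=C(C1=C(O)C3CCCC3N(Cc3ccccn3)C1=O)N2` carries pyridin-2-yl. In this assay compound 3 reaches only a limit of the assay, > 1 h (the limit of > 1 h in this assay, at which 1 of the 3 values shown sits). The steps to it read an at least 14-fold higher number from compound 1 to compound 3 (1.17 log units; beyond the scatter) and an at least 1.1-fold higher number from compound 2 to compound 3 (0.07 log units; that floor lies within the scatter).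

Compound 4 `CS(=O)(=O)Nc1ccc2c(c1)S(=O)(=O)N=C(C1=C(O)C3CCCC3N(Cc3ccccc3)C1=O)N2` differs from compound 3 by phenyl in place of pyridin-2-yl on a saturated chain carbon bound to an amide-type nitrogen in a ring. The step that bears most directly on this aryl-for-aryl change is an at least 1.1-fold higher number from compound 2 to compound 3 (0.07 log units; that floor lies within the scatter), whose floor lies within the scatter; the large steps from cyclobutyl bear less on it. Compound 4 is therefore expected to show a step of an at least 1.2-fold lower number from compound 3 to compound 4 (0.09 log units; that floor lies within the scatter) that need not exceed the scatter. The estimate for compound 4 is 0.8 h, with a range from 0.4 h to 1.6 h.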

Compound 4, half-life: 0.833 h
Compound 4: middle estimate off by 1.0-fold (0.02 log units), on the low side, and the stated range covers the measured number.
By their numbers in this assay, from the lowest: compound 1; then compounds 4 and 2 (each within the scatter of the next). At a limit, above all of these: compound 3.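

In this assay the plain phenyl arm already carries the large step away from cyclobutyl, a 12-fold higher number from compound 1 to compound 4 (1.10 log units; beyond the scatter), and adding fluoro does not separate the aryl arms, a 1.0-fold lower number from compound 2 to compound 4 (0.01 log units; within the scatter). The ring nitrogen of pyridin-2-yl gives only a floor for the change to phenyl, an at least 1.2-fold lower number from compound 3 to compound 4 (0.07 log units; that floor lies within the scatter), so neither fluoro nor that nitrogen is needed to reach the level of compound 4. The figure for compound 3 is a limit of the assay and not a number, so the true size of the pyridin-2-yl to phenyl change stays unknown: the limit of > 1 h in this assay, at which 1 of the 4 values shown sits.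

Open, on these data alone, is how an amine or a carboxylic acid on the phenyl ring, or a longer chain on the ring nitrogen, would read in this assay. Also open, as far as these compounds go, is whether a saturated ring such as piperidinyl would read like cyclobutyl or like the aryl groups.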